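Taking the chloro off compound 2

This account rests on a few compounds, and the source may have more. Where it says the series, first, only, none or still open, it means among the compounds named here.

In a functional assay on HOP-62 cells (Homo sapiens) for inhibition, read by sulforhodamine B assay (a higher number here means a weaker inhibitor of growth, a lower number a stronger inhibitor of growth), compound 2 (`Cc1ccc2[nH]c(-c3ccc(-c4ccc(-c5cccc(Cl)c5)cc4)cc3)nc2c1`) gives 2740 nM and shares the low end of the three numbers with compound 1 (`Cc1ccc2[nH]c(-c3ccc(-c4ccc(-c5ccc(N(C)C)cc5)cc4)cc3)nc2c1`) at 4230 nM within the scatter, while compound 3 (`Clc1cccc(-c2ccc(-c3ccc(-c4nc5ccccc5[nH]4)cc3)cc2)c1`) stands far off at 100000 nM as the high number. Compound 4 (`Cc1ccc2[nH]c(-c3ccc(-c4ccc(-c5ccccc5)cc4)cc3)nc2c1`) carries hydrogen in place of chloro on an aromatic carbon. The closest guide is the exchange of the whole 3-chlorophenyl group, which gave a 1.5-fold lower number from compound 1 to compound 2 (0.19 log units; within the scatter) and so stayed small. The large 36-fold higher number from compound 2 to compound 3 (1.56 log units; beyond the scatter) came with loss of the methyl, not the chloro, and says little here. No step beyond the scatter is therefore expected, and the estimated 1.3-fold higher number from compound 2 to compound 4 (0.11 log units; within the scatter) has no firm direction. Compound 4 is estimated at 3500 nM (range 1200 nM to 10000 nM).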

Compound 4, concentration for 50% growth inhibition: 39300 nM
For compound 4 the middle estimate is 11-fold (1.05 log units) below the measured one, outside the stated range (above it).
By their numbers in this assay, from the lowest: compounds 2 and 1 (each within the scatter of the next); then compound 4; then compound 3.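

In this assay the chloro turns out to matter: 3-chlorophenyl to phenyl gives a 14-fold higher number from compound 2 to compound 4 (1.16 log units; beyond the scatter) and leaves compound 4 the weaker inhibitor of growth. Hydrogen in place of dimethylamino also gives a step beyond the scatter, a 9.3-fold higher number from compound 1 to compound 4 (0.97 log units; beyond the scatter). Among these compounds, exchanging one of these groups for the other barely moved the number, yet having neither weakens growth inhibition clearly, which the earlier compounds could not show. As far as these compounds go, whether fluoro or methoxy on that ring would keep the number as low as chloro stays open. Nothing available here explains the loss.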